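The compounds below may be only part of what the source reports. "The series", "measured", "known", "first", "only" and "open" are said of these compounds alone.

Measured compounds, in an assay on isolated protein for inhibition of Tryptophan 2,3-dioxygenase (Homo sapiens), read by fluorescence and mass spectrometry, with stated times of 5 min and 15 min; a lower number here means a stronger inhibitor, a higher number a weaker inhibitor:
compound 1 `Nc1oncc1-c1ccccc1`, 140 nM
compound 2 `CNc1oncc1-c1ccccc1`, 190 nM
compound 3 `OCc1oncc1-c1ccccc1`, 4400 nM

Compound 1 gives the lowest number of the three. Its nearest neighbour is compound 2: a 1.4-fold higher number from compound 1 to compound 2 (0.13 log units; within the scatter). Compound 3 sits far off: a 31-fold higher number from compound 1 to compound 3 (1.50 log units; beyond the scatter), and likewise a 23-fold higher number from compound 2 to compound 3 (1.36 log units; beyond the scatter). Both large steps concern the substituent on the shared core; the phenyl ring is untouched in all three.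

Compound 4 `Nc1oncc1-c1ccc(Cl)cc1` differs from compound 1 in that ring only: chloro in place of hydrogen on an aromatic carbon. Within the data shown here, no measured step bears on this change; the series holds no pair differing on the six-membered aromatic ring of carbon only, so the steps from compound 1 to compound 2 and from compound 1 to compound 3 give no guidance here. With nothing to go on, the expected step in this assay is none beyond the scatter, in either direction: no change at the digits printed from compound 1 to compound 4 (within the scatter), estimated. For compound 4 the estimate is 140 nM, with a wide range from 35 nM to 560 nM to reflect the absence of any comparable step.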

Compound 4, half-maximal inhibitory concentration: 830 nM
Compound 4: middle estimate off by 5.9-fold (0.77 log units), on the low side; the whole stated range lies below it.
By their numbers in this assay, from the lowest: compounds 1 and 2 (each within the scatter of the next); then compound 4; then compound 3.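

The phenyl ring is not a silent part of the series in this assay: chloro in place of hydrogen on an aromatic carbon, para to a group of 6 heavy atoms, gives a 5.9-fold higher number from compound 1 to compound 4 (0.77 log units; beyond the scatter). Among these compounds, this is the first step read on the ring rather than on the substituent of the shared core, and it lies beyond the scatter, so this position responds to a change of a single heavy atom. Nothing measured here accounts for the weaker number.

As far as these compounds go, whether this step is particular to chloro remains open; fluoro, methyl, methoxy or a nitrile at the same position would test that. Also open, from the compounds shown here alone, are the other aromatic carbons of the ring, and chloro paired with the methylamino group of compound 2.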